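Aryl swap at the benzyl ether in an antiproliferative series

The compounds below may be only part of what the source reports. "The series", "measured", "known", "first", "only" and "open" are said of these compounds alone.

compound 1 `N#Cc1ccccc1COc1ccc(-c2cc(CN3CCN(Cc4ccc(C(F)(F)F)cc4)CC3)no2)cc1` 4000 nM
compound 2 `Fc1ccc(COc2ccc(-c3cc(CN4CCN(Cc5ccc(C(F)(F)F)cc5)CC4)no3)cc2)cc1` 7900 nM

In a functional assay on MCF7 cells (Homo sapiens) for antiproliferative activity, read by sulforhodamine B assay, with a stated time of 72 h (on this read-out lower numbers stand for stronger inhibition and higher numbers for weaker inhibition), compound 2 gives 7900 nM, the higher end of the two numbers shown, with compound 1 lying within the scatter of it. Compound 3 `COc1cc(COc2ccc(-c3cc(CN4CCN(Cc5ccc(C(F)(F)F)cc5)CC4)no3)cc2)cc(OC)c1` differs from compound 2 by 3,5-dimethoxyphenyl in place of 4-fluorophenyl on a saturated chain carbon bound to an oxygen on an aromatic ring. Among the measured compounds shown here, the only measured step at this position, a 2.0-fold higher number from compound 1 to compound 2 (0.30 log units; within the scatter), stayed within the scatter, so an aryl exchange here has not yet moved the number beyond it. The estimate for compound 3 therefore amounts to a 1.0-fold higher number from compound 2 to compound 3 (0.01 log units; within the scatter), no larger than the scatter. Compound 3 is expected at 8000 nM, with a range of 3000 nM to 20000 nM.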

Compound 3, half-maximal inhibitory concentration: 100 nM
Beside the measured number, compound 3's estimate is 80-fold (1.90 log units) above it; measured number outside the range, below it.
By their numbers in this assay, from the lowest: compound 3; then compounds 1 and 2 (each within the scatter of the next).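

In this assay the aryl group on a saturated chain carbon bound to an oxygen on an aromatic ring proves able to move the number far beyond the scatter: 3,5-dimethoxyphenyl gives large drops against both earlier groups (a 79-fold lower number from compound 2 to compound 3 (1.90 log units; beyond the scatter); a 40-fold lower number from compound 1 to compound 3 (1.60 log units; beyond the scatter)). The earlier exchange of 2-cyanophenyl for 4-fluorophenyl had shown no such reach. No measurement here accounts for this gain. The compounds shown leave open whether both methoxy groups are needed, and whether a single methoxy group would hold the gain. Nor do they say how ethoxy or hydroxy groups in their place would read.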